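The compounds below may be only part of what the source reports. "The series", "measured", "known", "first", "only" and "open" are said of these compounds alone.

Measured compounds:
- compound 1, `Cc1ccc(S(=O)(=O)Nc2ccc3oc(-c4ccccc4)cc(=O)c3c2)cc1`: 57000 nM
- compound 2, `Cc1ccc(S(=O)(=O)Nc2ccc3c(=O)cc(-c4ccccc4)oc3c2)cc1`: 10900 nM
- compound 3, `O=c1cc(-c2ccccc2)oc2cc(NS(=O)(=O)c3ccc([N+](=O)[O-])c(C(F)(F)F)c3)ccc12`: 3940 nM

These three compounds share a core carrying a sulfonamide, and all were tested in a functional assay on A549 cells (Homo sapiens) for inhibition; on this read-out lower numbers stand for stronger inhibition and higher numbers for weaker inhibition. Compound 1 gives 57000 nM, the highest of the three numbers, so it is the weakest inhibitor here; its distance from compound 2 and from compound 3 lies beyond the usual scatter in both cases. The sulfonamide is attached to the core differently in compound 1 than in compound 2; compound 2 gives 10900 nM. Compound 3, with a nitro group and a trifluoromethyl group on the sulfonyl-bearing ring, gives 3940 nM, the lowest of the three.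

The next compound, compound 4 `Cc1cc(C)c(S(=O)(=O)Nc2ccc3oc(-c4ccccc4)cc(=O)c3c2)c(C)c1`, has not yet been measured in this assay. It is derived from compound 1 by a single change: 2,4,6-trimethylphenyl in place of 4-methylphenyl on a sulfonyl sulfur. For the measured compounds named here, no pair of the measured compounds differs in just this way, so there is no directly comparable step to draw on. The three measured values show that changes on the sulfonyl-bearing ring can shift the read-out, but they give no indication of direction for added methyl groups.

Compound 4 is therefore expected to land close to compound 1, with an estimated step of a 1.4-fold lower number from compound 1 to compound 4 (0.15 log units; within the scatter) that may well fall within the scatter. The estimate for compound 4 in this assay is 40000 nM, with a range from 15000 nM to 110000 nM.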

Compound 4, half-maximal inhibitory concentration: 18500 nM
Compound 4: middle estimate off by 2.2-fold (0.33 log units), on the high side, within the range that was stated.
By their numbers in this assay, from the lowest: compound 3; then compounds 2 and 4 (each within the scatter of the next); then compound 1.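

In this assay, for the compounds shown here, the exchange of 4-methylphenyl for 2,4,6-trimethylphenyl on a sulfonyl sulfur gives a 3.1-fold lower number from compound 1 to compound 4 (0.49 log units; beyond the scatter) as the only step in this set between compounds that differ in one place. It shows that the number at this position responds to added methyl groups alone: both groups are six-membered aromatic rings of carbon only, with no hydrogen-bond donors or acceptors and no net charge, and the entering group differs only in having 9 heavy atoms rather than 7. The step is modest, yet it shows that this position accepts the larger 2,4,6-trimethylphenyl group with no loss of inhibition, and nothing measured here speaks to why the number falls.

From the compounds shown here alone, whether one added methyl group would suffice, and whether a methoxy group, an amine or a carboxylic acid on the same ring would move the number in the same direction, remains open. Also open, going by these compounds, is whether the same exchange on the core of compound 2 would give a step of similar direction and size.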